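Dithioacetal diacids: shortening the aryl ether chain

This account rests on a few compounds, and the source may have more. Where it says the series, first, only, none or still open, it means among the compounds named here.

Measured so far in an assay on membranes from lung (Cavia porcellus) for binding affinity to cysteinyl leukotriene receptor (Homo sapiens); a lower number here means a stronger inhibitor, a higher number a weaker inhibitor:
compound 1 `O=C(O)CCSC(SCCC(=O)O)c1ccccc1CCCCCCCCC1CCCCC1` gives 1960 nM
compound 2 `CCCCCCCCCC/C=C/c1ccccc1C(SCCC(=O)O)SCCC(=O)O` gives 491 nM
compound 3 `CCCCCCCCCCCOc1ccccc1C(SCCC(=O)O)SCCC(=O)O` gives 287 nM

Compound 3 carries the lowest number of the three in this assay. Its gap to compound 2 lies within the usual scatter, so the two cannot be placed in an order; only compound 1 stands apart from it, beyond the scatter. Among the compounds with values here, no pair among the three differs in a single place, so no measured step is available, and the three values only show that the side chain on the aromatic ring matters to some degree.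

Compound 4 `CCCCCCCCCOc1ccccc1C(SCCC(=O)O)SCCC(=O)O` is the next member. It differs from compound 3 as follows: hydrogen in place of ethyl on a saturated chain carbon, nine bonds along the chain from an oxygen on an aromatic ring. The shared core and both acid arms are kept; only the tail of the ether chain is shortened. Within the data shown here, with no measured step of this kind to lean on, the expectation is for a small step from compound 3 to compound 4 in this assay, more likely toward a higher number than a lower one, and quite possibly none beyond the scatter, giving an estimated 1.5-fold higher number from compound 3 to compound 4 (0.17 log units; within the scatter). Compound 4 is therefore estimated at 420 nM, with a range from 150 nM to 1200 nM.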

Compound 4, inhibition constant: 4090 nM
Compound 4: the middle estimate sits 9.7-fold (0.99 log units) below what was measured; measured number outside the range, above it.
By their numbers in this assay, from the lowest: compounds 3 and 2 (each within the scatter of the next); then compound 1; then compound 4.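

In this assay, the single-place step a 14-fold higher number from compound 3 to compound 4 (1.15 log units; beyond the scatter) gives the series its first measured comparison, and it is large: hydrogen in place of ethyl on a saturated chain carbon, nine bonds along the chain from an oxygen on an aromatic ring, is far from a neutral trim. The earlier compounds shown here showed only loosely that the side chain matters, with several features changing at once, whereas this step ties a clear loss of inhibition to the far end of the ether chain, with the shared core and both acid arms unchanged. Nothing measured here explains why the tail carries so much weight at this position.

The compounds shown leave open whether the rise in the number is gradual or abrupt along the chain, since only one pair of ether chain lengths can be read, and whether a longer chain than that of compound 3 would lower the number further. Also open, from the compounds shown here alone, is whether a group other than a plain alkyl tail, such as an amine or a carboxylic acid at the chain end, would be accepted at this place.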